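The compounds below may be only part of what the source reports. "The series", "measured", "known", "first", "only" and "open" are said of these compounds alone.

Measured compounds:
- compound 1, `CO[C@@H]1CC=C2NN(c3ccc(C)cc3)C(=O)C[C@]2(C)O1`: 29700 nM
- compound 2, `CO[C@@H]1CC=C2NN(c3ccc(C)cc3)C(=O)C[C@]2(c2ccncc2)O1`: 6200 nM
- compound 3, `COc1cc(OC)cc(N2NC3=CC[C@@H](OC)O[C@@]3(C)CC2=O)c1`: 5700 nM

These three compounds were tested in a functional assay on SK-BR-3 cells (Homo sapiens) for inhibition, read by sulforhodamine B assay, with a stated time of 48 h; a higher number here means a weaker inhibitor, a lower number a stronger inhibitor. Compound 1 and compound 2 share a core and differ in one place: pyridin-4-yl in place of methyl on a saturated ring carbon That single change gave a 4.8-fold lower number from compound 1 to compound 2 (0.68 log units; beyond the scatter), so the pyridin-4-yl compound is the stronger inhibitor of the two. Compound 3 carries a different aryl group on the ring nitrogen; how its core differs from that of compound 1 is not broken down here. In this assay compound 3 gives a number close to that of compound 2, and the two lie within the scatter of each other.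

Compound 4, `COc1cc(OC)cc(N2NC3=CC[C@@H](OC)O[C@@]3(c3ccncc3)CC2=O)c1`, has not yet been measured. Among the measured compounds shown here, it differs from compound 3 in one place: pyridin-4-yl in place of methyl on a saturated ring carbon This is the same kind of change as the one from compound 1 to compound 2, though the surroundings are described differently: in compound 4 the carbon is part of a six-membered non-aromatic ring with two nitrogen, while in compound 2 it is described as part of a six-membered non-aromatic ring with one oxygen, next to the ring oxygen. For the measured compounds named here, because a 4.8-fold lower number from compound 1 to compound 2 (0.68 log units; beyond the scatter) was seen for the same group swap, a step of similar size is expected here, with some caution since only one earlier example exists. The estimated step is a 3.8-fold lower number from compound 3 to compound 4 (0.58 log units; beyond the scatter). Compound 4 is expected to give about 1500 nM in this assay, likely between 600 nM and 5000 nM.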

Compound 4, half-maximal inhibitory concentration: 210 nM
Beside the measured number, compound 4's estimate is 7.1-fold (0.85 log units) above it; the whole stated range lies above it.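

In this assay, putting pyridin-4-yl in place of methyl on the saturated ring carbon again lowered the number, with a 27-fold lower number from compound 3 to compound 4 (1.43 log units; beyond the scatter) as the new step, so the direction of the change held on both cores. The size of the step did not hold, and the gain on the core of compound 3 was clearly larger than on the core of compound 1: the same change on two cores in this assay, a 4.8-fold lower number (0.68 log units; beyond the scatter) from compound 1 to compound 2 and a 27-fold lower number (1.43 log units; beyond the scatter) from compound 3 to compound 4, 5.7-fold (0.75 log units) apart, beyond the scatter of two such steps. These two pairs show that the swap strengthened inhibition on both cores in this series, but a gain measured on one core did not give its size on the other, and they do not show why the two gains differ or whether a third core would follow either one.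

The compounds shown compare only methyl and pyridin-4-yl at this carbon, so it stays open whether phenyl or pyridin-3-yl there would give a step of similar size. As far as these compounds go, the two cores differ in the aryl group on the ring nitrogen, and it also stays open how the step would change with another group in that place, such as an unsubstituted phenyl or a 4-chlorophenyl.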